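This account rests on a few compounds, and the source may have more. Where it says the series, first, only, none or still open, it means among the compounds named here.

Compound 2 (`CN1CCC(c2c[nH]c3ccc(NC(=O)c4cccc(F)c4)nc23)CC1`) gives 1600 nM in an assay for binding affinity to 5-hydroxytryptamine receptor 1B (Homo sapiens), read by radioligand binding (a higher number here means a weaker inhibitor, a lower number a stronger inhibitor), the highest of the three numbers measured there: compound 1 (`CCCCCCCC(=O)Nc1ccc2[nH]cc(C3CCN(C)CC3)c2n1`) gives 32 nM and compound 3 (`CN1CCC(c2c[nH]c3ccc(NC(=O)c4ccc([N+](=O)[O-])cc4)nc23)CC1`) gives 270 nM. Compound 4 (`CN1CCC(c2c[nH]c3ccc(NC(=O)c4ccncc4)nc23)CC1`) differs from compound 2 by pyridin-4-yl in place of 3-fluorophenyl on a carbonyl carbon. All three measured steps alter the same carbonyl carbon: a 50-fold higher number from compound 1 to compound 2 (1.70 log units; beyond the scatter), an 8.4-fold higher number from compound 1 to compound 3 (0.93 log units; beyond the scatter) and a 5.9-fold lower number from compound 2 to compound 3 (0.77 log units; beyond the scatter). Among the measured compounds shown here, the change to compound 4 has no direct precedent, but swapping one six-membered aromatic ring for another at this position moved this assay modestly, and a ring with a hetero atom has not yet been measured. Compound 4 is therefore expected to show a 2.3-fold lower number from compound 2 to compound 4 (0.36 log units; beyond the scatter), with an estimate of 700 nM and a range from 180 nM to 2800 nM.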

Compound 4, inhibition constant: 330 nM
Estimate against measurement, compound 4: 2.1-fold (0.33 log units) above, and the stated range covers the measured number.
By their numbers in this assay, from the lowest: compound 1; then compounds 3 and 4 (each within the scatter of the next); then compound 2.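

Pyridin-4-yl, the only ring with a hetero atom shown at this carbonyl carbon, gives a 4.8-fold lower number from compound 2 to compound 4 (0.69 log units; beyond the scatter) in this assay and so shows that replacing 3-fluorophenyl with this ring lowers the number. Against 4-nitrophenyl it gives a 1.2-fold higher number from compound 3 to compound 4 (0.09 log units; within the scatter) and the two compounds cannot be told apart. Heptyl still stands apart, with a 10-fold higher number from compound 1 to compound 4 (1.01 log units; beyond the scatter) and compound 1 keeps the lowest number against all three aromatic rings shown.

Nothing shown gives a reason for these steps. From the compounds shown here alone, whether a chain longer than heptyl or a cyclohexyl ring on this carbonyl carbon would lower the number further remains open.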